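The source may report more compounds than this note shows. Statements on the series, on what has been measured and on what is new or still open speak of the compounds shown alone.

Measured compounds:
compound 1 `COC(=O)c1cccc(NC(=O)c2cc3cc([N+](=O)[O-])ccc3o2)c1`, a physicochemical assay for solubility; a lower number here means a less soluble compound, a higher number a more soluble compound: 25 ug/mL
compound 2 `NC(=O)c1ccccc1NC(=O)c1cc2cc([N+](=O)[O-])ccc2o1`, this assay: 5 ug/mL
compound 3 `NC(=O)c1cccc(NC(=O)c2cc3cc([N+](=O)[O-])ccc3o2)c1`, this assay: 20 ug/mL

In this assay compound 3 stands second highest of the three numbers. Its nearest neighbour is compound 1, whose value of 25 ug/mL lies within the scatter of compound 3, so no order between them is claimed. Compound 2 gives 5 ug/mL, a lower number than compound 3 that lies beyond the scatter.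

Compound 4 `O=C(Nc1ccccc1)c1cc2cc([N+](=O)[O-])ccc2o1` differs from compound 3 by hydrogen in place of carbamoyl on an aromatic carbon, on an aromatic carbon of a six-membered aromatic ring of carbon only, meta to a large group. Within the data shown here, the only measured step concerns this same position: a 1.3-fold lower number from compound 1 to compound 3 (0.10 log units; within the scatter). Among the measured compounds shown here, that step swaps one group for another and does not remove the group, so it bears on the change only loosely; no measured pair shows the group removed altogether. For the measured compounds named here, with no direct precedent, the expected change in this assay is modest, and compound 4 is estimated to sit near compound 3 or somewhat lower, the expected step being a 1.7-fold lower number from compound 3 to compound 4 (0.22 log units; within the scatter). The estimate for compound 4 in this assay is 12 ug/mL, with a range from 4 ug/mL to 40 ug/mL.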

Compound 4, solubility: 25 ug/mL
Beside the measured number, compound 4's estimate is 2.1-fold (0.32 log units) below it; low and high end bracket the measured number.
By their numbers in this assay, from the lowest: compound 2; then compounds 3, 1 and 4 (each within the scatter of the next).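

In this assay, the position tolerates loss of its substituent without a change that clears the scatter: replacing carbamoyl with hydrogen gives a 1.3-fold higher number from compound 3 to compound 4 (0.10 log units; within the scatter), and replacing methoxycarbonyl with hydrogen gives no change at the digits printed from compound 1 to compound 4 (within the scatter). The same replacement starting from compound 2, where carbamoyl stands on a different carbon of the ring, gives a 5.0-fold higher number from compound 2 to compound 4 (0.70 log units; beyond the scatter), so among these compounds only that placement goes with a number set apart from the rest. No measurement on hand offers a reason for either result.

From the compounds shown here alone, whether an amine, a carboxylic acid or a longer chain at this position would also stay within the scatter of compound 4 remains open. So does whether the other ring carbons respond as the carbon bearing the carbamoyl in compound 2 does.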